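Series notes: 5-chloro-2-hydroxyphenyl in place of 3-bromo-4-hydroxyphenyl

The source may report more compounds than this note shows. Statements on the series, on what has been measured and on what is new or still open speak of the compounds shown alone.

Compound 3 `COc1ccc(C(=O)/C=C/c2ccc(O)c(Br)c2)c2c1C=CC(C)(C)O2` stands at the edge of what a functional assay on HT-29 cells (Homo sapiens) for antiproliferative activity, read by MTT assay, with a stated time of 24 h (a lower number here means a stronger inhibitor, a higher number a weaker inhibitor), can report: in this assay compound 3 gives > 10000 nM, a limit and not a number. Compound 1 `COc1cccc(/C=C/C(=O)c2ccc(OC)c3c2OC(C)(C)C=C3)c1` in this assay gives > 10000 nM, also a limit. Compound 2 `COc1ccc(C(=O)/C=C/c2ccco2)c2c1C=CC(C)(C)O2` in this assay gives > 10000 nM, again a limit. All three rest on the same line, (the limit of > 10000 nM in this assay, at which 3 of the 3 values shown sit), so the steps a step that the two limits leave unreadable from compound 1 to compound 2, a step that the two limits leave unreadable from compound 1 to compound 3 and a step that the two limits leave unreadable from compound 2 to compound 3 cannot be read in size or direction. Compound 4 `COc1ccc(C(=O)/C=C/c2cc(Cl)ccc2O)c2c1C=CC(C)(C)O2` differs from compound 3 by 5-chloro-2-hydroxyphenyl in place of 3-bromo-4-hydroxyphenyl on a double-bonded chain carbon bound to a double-bonded chain carbon. Within the data shown here, no measured step bears on this swap, and the three limits give no scale for it. Compound 4 is therefore expected to stay near the limit as well, with an estimated step that the limit leaves unreadable from compound 3 to compound 4. The estimate for compound 4 in this assay is 20000 nM, with a range of 5000 nM to 80000 nM.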

Compound 4, half-maximal inhibitory concentration: 4970 nM
Compound 4: middle estimate off by 4.0-fold (0.60 log units), on the high side; the whole stated range lies above it.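

Compound 4 is the only compound shown that gives a number in this assay and does not rest on the limit: the limit of > 10000 nM in this assay, at which 3 of the 4 values shown sit.
A group on a double-bonded chain carbon bound to a double-bonded chain carbon can therefore bring this series inside the range of the assay, as 5-chloro-2-hydroxyphenyl does in each comparison (an at least 2.0-fold lower number from compound 3 to compound 4 (0.30 log units; that floor lies within the scatter); an at least 2.0-fold lower number from compound 2 to compound 4 (0.30 log units; that floor lies within the scatter); an at least 2.0-fold lower number from compound 1 to compound 4 (0.30 log units; that floor lies within the scatter)). Each of these steps is a floor, so its true size stays unread, and the steps among compound 1, compound 2 and compound 3 cannot be read at all.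

Going by these compounds, the swap alters the halogen and the hydroxyl together, so what carries the change stays open. A 2-hydroxyphenyl group without chlorine, or a 5-chloro-2-aminophenyl group, would separate the two.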